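A few compounds are considered here, and "the series" means these few. Any claim that something is new, unique, unknown or untested is made for them only; others in the source may bear on it.

Compound 1 `O=C1N=C(N2CCC[C@H]2C(=O)Nc2ccc3ncnc(Nc4cccc(Cl)c4)c3c2)S/C1=C/c1cccnc1Cl`: 10800 nM
Compound 2 `O=C1N=C(N2CCC[C@H]2C(=O)Nc2ccc3ncnc(Nc4cccc(Cl)c4)c3c2)S/C1=C/c1ccccc1[N+](=O)[O-]`: > 50000 nM (a limit of the assay)
Compound 3 `O=C1N=C(N2CCC[C@H]2C(=O)Nc2ccc3ncnc(Nc4cccc(Cl)c4)c3c2)S/C1=C/c1ccccc1F`: 34500 nM

In a functional assay on A549 cells (Homo sapiens) for antiproliferative activity, read by MTT assay (on this read-out lower numbers stand for stronger inhibition and higher numbers for weaker inhibition), compound 3 gives 34500 nM, the highest of the two numbers shown. Its nearest neighbour is compound 1, which in this assay gives 10800 nM, and the step between them is a 3.2-fold higher number from compound 1 to compound 3 (0.50 log units; beyond the scatter). For compound 2 the read-out is not a number but a limit of the assay, > 50000 nM (the limit of > 50000 nM in this assay, at which 1 of the 3 values shown sits).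

Compound 4 `O=C1N=C(N2CCC[C@H]2C(=O)Nc2ccc3ncnc(Nc4cccc(Cl)c4)c3c2)S/C1=C/c1ccc2ccccc2n1` differs from compound 3 by quinolin-2-yl in place of 2-fluorophenyl on a double-bonded chain carbon bound to a double-bonded ring carbon. Both measured changes at this carbon start from compound 1: a 3.2-fold higher number from compound 1 to compound 3 (0.50 log units; beyond the scatter) and an at least 4.6-fold higher number from compound 1 to compound 2 (0.66 log units; beyond the scatter). Between the two phenyl groups themselves the difference is small: an at least 1.4-fold lower number from compound 2 to compound 3 (0.16 log units; that floor lies within the scatter). Among the measured compounds shown here, the one group carrying a ring nitrogen, in compound 1, gave the lowest number; quinolin-2-yl also carries a ring nitrogen, but it is larger than any group measured here, so a step downward is expected, yet of modest size and with wide uncertainty.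

Compound 4 is therefore estimated at 15000 nM in this assay, with a range from 4000 nM to 50000 nM. This corresponds to an expected step of a 2.3-fold lower number from compound 3 to compound 4 (0.36 log units; beyond the scatter).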

Compound 4, half-maximal inhibitory concentration: > 50000 nM
Compound 4 ended at the assay's limit; the forecaster's own chance of this, stated with the estimate: 20%; at least 3.3-fold (0.52 log units) between middle value and limit.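

In this assay the read-out of compound 4 is a limit of the assay, > 50000 nM, and it is the second compound to end there: the limit of > 50000 nM in this assay, at which 2 of the 4 values shown sit. Quinolin-2-yl carries a ring nitrogen, as 2-chloropyridin-3-yl does, yet this change gives an at least 4.6-fold higher number from compound 1 to compound 4 (0.66 log units; beyond the scatter), so a ring nitrogen alone does not bring the number down, and among the four compounds the lowest number stays with compound 1. Putting quinolin-2-yl in place of 2-fluorophenyl gives an at least 1.4-fold higher number from compound 3 to compound 4 (0.16 log units; that floor lies within the scatter), a floor that lies within the scatter and so fixes no firm order between these two groups, while the step that joins the two limits cannot be read.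

The compounds shown do not separate the ring nitrogen of compound 1 from its chloro group, and a plain pyridin-3-yl or a 2-chlorophenyl group on the double-bonded chain carbon would divide the two. Also open, as far as these compounds go, is whether an amine or a carboxylic acid on the phenyl ring at this carbon would move the number in either direction.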